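Diisopropylamino step from compound 3 to compound 4

The source may report more compounds than this note shows. Statements on the series, on what has been measured and on what is new or still open speak of the compounds shown alone.

Measured so far in a functional assay on SW480 cells (Homo sapiens) for antiproliferative activity, read by MTT assay, with a stated time of 48 h; a lower number here means a stronger inhibitor, a higher number a weaker inhibitor
- compound 1 `CC(=O)OC/C1=C/C[C@](C)(CCC=C(C)C)/C=C/[C@@H](OC(=O)C=C(C)C)[C@](C)(O)/C=C/C1=O` gives 2950 nM
- compound 2 `CC(C)=CCC[C@]1(C)/C=C/[C@@H](OC(=O)C=C(C)C)[C@](C)(O)/C=C/C(=O)/C(CN(C)C)=C\C1` gives 480 nM
- compound 3 `CCN(CC)C/C1=C/C[C@](C)(CCC=C(C)C)/C=C/[C@@H](OC(=O)C=C(C)C)[C@](C)(O)/C=C/C1=O` gives 270 nM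

Compound 3 stands in the low group of the three numbers, with a 1.8-fold lower number from compound 2 to compound 3 (0.25 log units; within the scatter) separating it from its nearest neighbour. Compound 4 `CC(C)=CCC[C@]1(C)/C=C/[C@@H](OC(=O)C=C(C)C)[C@](C)(O)/C=C/C(=O)/C(CN(C(C)C)C(C)C)=C\C1` carries the change diisopropylamino in place of diethylamino on a saturated chain carbon bound to a double-bonded ring carbon on a saturated chain carbon bound to a double-bonded ring carbon. The steps of a 6.1-fold lower number from compound 1 to compound 2 (0.79 log units; beyond the scatter) and an 11-fold lower number from compound 1 to compound 3 (1.04 log units; beyond the scatter) replaced acetoxy and bear only loosely on this change. Among the measured compounds shown here, the amine-for-amine step is the closest precedent and lies within the scatter, so no step beyond the scatter is expected in this assay for compound 4. The expected outcome is a 1.1-fold higher number from compound 3 to compound 4 (0.05 log units; within the scatter) at the estimate. For compound 4 the expected value is 300 nM within a range from 110 nM to 800 nM as estimated here.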

Compound 4, half-maximal inhibitory concentration: 750 nM
Estimate against measurement, compound 4: 2.5-fold (0.40 log units) below; the measured number falls inside the stated range.
By their numbers in this assay, from the lowest: compounds 3, 2 and 4 (each within the scatter of the next, the first and the last beyond it); then compound 1.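

In this assay, among the compounds shown here, a 2.8-fold higher number from compound 3 to compound 4 (0.44 log units; beyond the scatter) is the first amine-for-amine step at this place to lie beyond the scatter, whereas a 1.6-fold higher number from compound 2 to compound 4 (0.19 log units; within the scatter) stays within it, so the three amines do not separate evenly. The diisopropylamino group still retains a gain over acetoxy, with a 3.9-fold lower number from compound 1 to compound 4 (0.59 log units; beyond the scatter) as the step. No measured evidence accounts for these differences. Open, going by these compounds, is how a cyclic amine such as pyrrolidine or morpholine on the same saturated chain carbon would compare with the diethylamino group of compound 3 in this assay.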